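The source may hold more compounds than are shown below. What is called first, only, known or untested is meant among the compounds shown, and "the series" means these compounds.

Measured so far in an ADME assay on the whole organism for pharmacokinetics, with Rattus norvegicus as the target, at a dose of 1 mg/kg by the oral route; on this read-out higher numbers stand for higher exposure at the dose given and lower numbers for lower exposure:
compound 1 `CC(C)CC1(O)CCN(C(=O)Nc2cc(Oc3ccc(F)cc3)cc(Oc3ccc(CC(=O)O)cc3)c2)CC1` gives 237 nM
compound 2 `CC(C)CC1(O)CCN(C(=O)Nc2cc(Oc3ccc(F)cc3)cc(Oc3ccc(C(C)(C)C(=O)O)cc3)c2)CC1` gives 156 nM
compound 3 `CC(C)CC1(O)CCN(C(=O)Nc2cc(Oc3ccc(F)cc3)cc(Oc3ccc(C4(C(=O)O)CC4)cc3)c2)CC1` gives 110 nM

For the measured compounds named here, compound 3 stands lowest of the three in this assay; against compound 2 the gap is within the scatter, and only the step from compound 1 counts as a real difference: a 2.2-fold lower number from compound 1 to compound 3 (0.33 log units; beyond the scatter). The other measured steps are a 1.5-fold lower number from compound 1 to compound 2 (0.18 log units; within the scatter) and a 1.4-fold lower number from compound 2 to compound 3 (0.15 log units; within the scatter).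

Compound 4 `CC(C)CC1(O)CCN(C(=O)Nc2cc(Oc3ccc(F)cc3)cc(Oc3ccc(C(=O)O)cc3F)c2)CC1` is the next candidate. The change from compound 3 is 4-carboxy-2-fluorophenyl in place of 4-(1-carboxycyclopropyl)phenyl on an oxygen on an aromatic ring. Going by the values given here, none of the measured steps covers this change directly: they vary the group that carries the acid on the same phenyl, whereas here the acid is moved onto the ring itself and a fluorine enters the ring. The three measured steps were all small, and the simplest acid, compound 1, gave the highest number, so in this assay no step beyond the scatter is expected for compound 4, with the direction, if any, slightly upward: a 1.5-fold higher number from compound 3 to compound 4 (0.19 log units; within the scatter). Compound 4 is therefore estimated at 170 nM in this assay, within a range of 60 nM to 500 nM.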

Compound 4, maximal plasma concentration: 27.8 nM
Beside the measured number, compound 4's estimate is 6.1-fold (0.79 log units) above it; measured number outside the range, below it.
By their numbers in this assay, from the lowest: compound 4; then compounds 3, 2 and 1 (each within the scatter of the next, the first and the last beyond it).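

In this assay, 4-carboxy-2-fluorophenyl in place of 4-(1-carboxycyclopropyl)phenyl gives a 4.0-fold lower number from compound 3 to compound 4 (0.60 log units; beyond the scatter) as a step, and the same exchange of the whole group gives a 5.6-fold lower number from compound 2 to compound 4 (0.75 log units; beyond the scatter) as well as an 8.5-fold lower number from compound 1 to compound 4 (0.93 log units; beyond the scatter) as its other two steps. Compound 4 therefore stands lowest of the four, beyond the scatter from each of the others, so replacing the whole group on this oxygen moves the number further than any earlier change to the group carrying the acid on the same phenyl. Nothing at hand explains this fall in exposure.

Two changes arrive together in compound 4, so the share of the fluorine cannot be separated from that of the shortened acid attachment. Open questions are how the plain 4-carboxyphenyl group would read and how chlorine in place of the fluorine would read.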